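Methylsulfonyl in place of methyl on a nitro-bearing ring

The source may report more compounds than this note shows. Statements on the series, on what has been measured and on what is new or still open speak of the compounds shown alone.

Measured so far:
Compound 1 `O=[N+]([O-])c1cccc(CNc2cc(Br)cc3[nH]ncc23)c1`, 72%
Compound 2 `Cc1ccc(CNc2cc(C(F)(F)F)cc3[nH]ncc23)c([N+](=O)O)c1`, 36%

In an assay for inhibition of Indoleamine 2,3-dioxygenase 1 (Homo sapiens), with stated times of 10 min and 60 min, tested at 10 uM (on this read-out higher numbers stand for a stronger effect at the one concentration tested and lower numbers for a weaker effect), compound 2 stands lowest of the two numbers, and compound 1 lies well above it, beyond the scatter. Compound 3 `CS(=O)(=O)c1ccc(CNc2cc(C(F)(F)F)cc3[nH]ncc23)c([N+](=O)O)c1` is the unmeasured partner of compound 2. The change is methylsulfonyl in place of methyl on an aromatic carbon. Among the measured compounds shown here, no step between measured compounds is known, so nothing in the data says how such a change shifts the read-out in this assay. A step within the scatter, or a small loss, is expected from compound 2 to compound 3, a number 6 percentage points lower from compound 2 to compound 3 (within the scatter). Compound 3 is estimated at 30%, with a range from 10% to 55%.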

Compound 3, a percentage reported as inhibition, at one concentration (the size of the read-out at that concentration, not a potency): 63%
Compound 3: the middle estimate sits 33 percentage points below what was measured, and the stated range ends below it.
By their numbers in this assay, from the lowest: compound 2; then compounds 3 and 1 (each within the scatter of the next).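

In this assay the swap of methyl for methylsulfonyl on an aromatic carbon gives a number 27 percentage points higher from compound 2 to compound 3 (beyond the scatter) and so shows that this position, para to a large group, tolerates the larger group and that the read-out responds to what sits there. It is the only one-place step shown, so it describes this single pair and sets no trend. No measurement shown accounts for the rise.
As far as these compounds go, whether an amine, a carboxylic acid or a nitrile at this position would give a similar read-out stays open. So does whether the same swap would have a similar effect on another core.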